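Swapping methoxy for methylsulfanyl on a second nucleoside core

A few compounds are considered here, and "the series" means these few. Any claim that something is new, unique, unknown or untested is made for them only; others in the source may bear on it.

Three nucleoside analogues have been tested in a functional assay on K562 cells (Homo sapiens), read by MTT assay, with a stated time of 72 h; on this read-out lower numbers stand for stronger inhibition and higher numbers for weaker inhibition. Compound 1 `COc1ncnc2c1c(-c1cccs1)cn2[C@@H]1O[C@H](CO)[C@@H](O)[C@H]1O` gives 70 nM. Compound 2 `CSc1ncnc2c1c(-c1cccs1)cn2[C@@H]1O[C@H](CO)[C@@H](O)[C@H]1O` carries a change marked by methylsulfanyl in place of methoxy on an aromatic carbon and gives 11600 nM, so that a 170-fold higher number from compound 1 to compound 2 (2.22 log units; beyond the scatter). Compound 3 `C#Cc1cn([C@@H]2O[C@H](CO)[C@@H](O)[C@H]2O)c2ncnc(OC)c12` differs from compound 1 in its core by ethynyl in place of thiophen-2-yl on an aromatic carbon, and in this assay compound 3 gives 300 nM, a step of a 4.3-fold higher number from compound 1 to compound 3 (0.63 log units; beyond the scatter).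

Compound 4 `C#Cc1cn([C@@H]2O[C@H](CO)[C@@H](O)[C@H]2O)c2ncnc(SC)c12` has not yet been measured. Among the compounds with values here, it is made from compound 3 by methylsulfanyl in place of methoxy on an aromatic carbon, the same change as the one from compound 1 to compound 2, at a place described in the same words, on a core that differs only by the ethynyl in place of thiophen-2-yl.

Because a 170-fold higher number from compound 1 to compound 2 (2.22 log units; beyond the scatter), a large weakening is expected again, and the estimate for this assay is a 130-fold higher number from compound 3 to compound 4 (2.12 log units; beyond the scatter). Within the data shown here, compound 4 is therefore expected to give about 40000 nM, with a range from 8000 nM to 150000 nM, resting on only one earlier instance of this change.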

Compound 4, half-maximal inhibitory concentration: 30 nM
Beside the measured number, compound 4's estimate is 1300-fold (3.12 log units) above it; measured number below the stated range.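

The swap of methoxy for methylsulfanyl did not carry over from one core to the other in this assay; with ethynyl in place of thiophen-2-yl, it gives a 10-fold lower number from compound 3 to compound 4 (1.00 log units; beyond the scatter), and the direction of the earlier step is reversed: the same change on two cores in this assay, a 170-fold higher number (2.22 log units; beyond the scatter) from compound 1 to compound 2 and a 10-fold lower number (1.00 log units; beyond the scatter) from compound 3 to compound 4, 1700-fold (3.22 log units) apart, beyond the scatter of two such steps

Read the other way round, the change of thiophen-2-yl to ethynyl also depends on its partner group, since with methylsulfanyl already present it gives a 390-fold lower number from compound 2 to compound 4 (2.59 log units; beyond the scatter): the same change on two cores in this assay, a 4.3-fold higher number (0.63 log units; beyond the scatter) from compound 1 to compound 3 and a 390-fold lower number (2.59 log units; beyond the scatter) from compound 2 to compound 4, 1700-fold (3.22 log units) apart, beyond the scatter of two such steps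

These four compounds show that the two changes do not act independently here, so a step measured on one core is a poor guide to the same step on the other, but they give one pair per core and do not reveal why the direction reverses.

As far as these compounds go, it remains open whether an amine or a longer chain in the place of the methoxy would follow the pattern seen with thiophen-2-yl or that seen with ethynyl. A phenyl ring in the place of the ethynyl would test whether the reversal extends beyond these two cores.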